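The source may hold more compounds than are shown below. What is called first, only, known or untested is meant among the compounds shown, and "the series" means these compounds.

In a functional assay on MCF7 cells (Homo sapiens) for cytotoxicity, read by MTT assay, with a stated time of 72 h (a lower number here means a stronger inhibitor of growth, a higher number a weaker inhibitor of growth), compound 1, `CCCCCSc1nc(NCc2ccc([Se]C)cc2)c2ccccc2n1`, gives 13000 nM. Compound 2, `CSc1nc(NCc2ccc([Se]C)cc2)c2ccccc2n1`, differs from it by hydrogen in place of butyl on a saturated chain carbon bound to a sulfur, and in this assay compound 2 gives 36400 nM. That change produced a 2.8-fold higher number from compound 1 to compound 2 (0.45 log units; beyond the scatter).

Compound 3, `CCCCC[Se]c1nc(N)c2cccnc2n1`, carries a different core; the difference between the two cores is not broken down here. In this assay compound 3 gives 22700 nM, a value that sits within the scatter of both compound 2 and compound 1, so no order among the three can be read from it.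

Compound 4, `C[Se]c1nc(N)c2cccnc2n1`, has not yet been measured. It differs from compound 3 by hydrogen in place of butyl on a saturated chain carbon bound to a selenium atom. For the measured compounds named here, this is the same kind of change as the one from compound 1 to compound 2, since in both cases butyl leaves and hydrogen enters on a saturated chain carbon; what differs around the place is that in compound 1 the chain carbon is bound to a sulfur, while in compound 3 it is bound to a selenium atom.

Resting on the step of a 2.8-fold higher number from compound 1 to compound 2 (0.45 log units; beyond the scatter), compound 4 is expected to show a 2.6-fold higher number from compound 3 to compound 4 (0.42 log units; beyond the scatter) relative to compound 3. Accordingly compound 4 is estimated at 60000 nM in this assay, with an expected range from 25000 nM to 150000 nM.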

Compound 4, concentration for 50% growth inhibition: 43000 nM
The estimate for compound 4 lay 1.4-fold (0.14 log units) above the measured number; the measured number falls inside the stated range.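

In this assay, replacing butyl with hydrogen on a saturated chain carbon bound to a selenium atom gives a 1.9-fold higher number from compound 3 to compound 4 (0.28 log units; within the scatter), so on this core the pentyl to methyl difference cannot be told apart from the scatter of repeated measurements. Set beside the step on the core of compound 1, this change does not read measurably differently on the two cores: the same change on two cores in this assay, a 2.8-fold higher number (0.45 log units; beyond the scatter) from compound 1 to compound 2 and a 1.9-fold higher number (0.28 log units; within the scatter) from compound 3 to compound 4, 1.5-fold (0.17 log units) apart, within the scatter of two such steps. For the compounds shown here, that agreement shows only that the two steps are compatible and does not establish that the change carries over in full, as just the step on the core of compound 1 stands beyond the scatter, the two pairs differ in sulfur and selenium as well as in core, and each core is represented by a single pair.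

The compounds shown leave open how a propyl chain, a longer chain such as octyl, or a chain carrying an amine or a carboxylic acid would read in this assay on either core. They also leave open how sulfur and selenium compare at this place on one and the same core, which would separate the contribution of that atom from that of the core.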